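Sulfonamide benzamides: lipophilicity notes before compound 4

This account rests on a few compounds, and the source may have more. Where it says the series, first, only, none or still open, it means among the compounds named here.

Of the compounds shown here, three have been measured in a physicochemical assay for lipophilicity, using the shake flask method, in phosphate buffer, measured as octanol-water partition, at pH 7.4; a higher number here means a more lipophilic compound, a lower number a more polar compound. Compound 1 `Cc1noc(CNC(=O)c2ccc(C)c(S(=O)(=O)Nc3ccc(Cl)cc3)c2)n1` gives 3. Compound 2 `Cc1ccc(C(=O)NCc2cn(C)nn2)cc1S(=O)(=O)Nc1ccc(-c2ccno2)cc1` gives 2.4 in this assay. Compound 3 `Cc1noc(CNC(=O)c2ccc(C)c(S(=O)(=O)Nc3ccc(-c4ccno4)cc3)c2)n1` gives 2.3 in this assay. The cores of compound 2 and compound 3 differ only at the saturated chain carbon: 1-methyl-1H-1,2,3-triazol-4-yl in place of 3-methyl-1,2,4-oxadiazol-5-yl on a saturated chain carbon bound to an amide-type nitrogen. That step, a number 0.10 log units lower from compound 2 to compound 3 (within the scatter), is within the scatter, so the two cores cannot be told apart on this read-out. Compound 3 and compound 1 differ at the aromatic carbon: chloro in place of 1,2-oxazol-5-yl on an aromatic carbon. That step is a number 0.70 log units higher from compound 3 to compound 1 (beyond the scatter).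

Compound 4 `Cc1ccc(C(=O)NCc2cn(C)nn2)cc1S(=O)(=O)Nc1ccc(Cl)cc1` is not yet measured. It stands to compound 2 as compound 1 stands to compound 3, the same change at a place described in the same words: chloro in place of 1,2-oxazol-5-yl on an aromatic carbon. Among these four compounds the change occurs twice, once with a measured result. The expected step is a number 0.70 log units higher from compound 2 to compound 4 (beyond the scatter), resting on the measured a number 0.70 log units higher from compound 3 to compound 1 (beyond the scatter) and on the near-identity of the two cores shown by a number 0.10 log units lower from compound 2 to compound 3 (within the scatter). With a single precedent the width is kept generous. Compound 4 is therefore estimated at 3.1, between 2.7 and 3.5.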

Compound 4, distribution coefficient: 2.9
The estimate for compound 4 lay 0.20 log units above the measured number; measured number inside the range.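

In this assay, chloro in place of 1,2-oxazol-5-yl gives a number 0.50 log units higher from compound 2 to compound 4 (beyond the scatter) on one core and a number 0.70 log units higher from compound 3 to compound 1 (beyond the scatter) on the other, so the direction of the change carries across these two cores, and with chloro present the cores still cannot be told apart, with a number 0.10 log units lower from compound 1 to compound 4 (within the scatter) in this pair. Going by these compounds alone, this is only two observations on cores that differ in one group on the saturated chain carbon, so it shows neither a fixed size for the step nor that the change would carry to a more distant core. No measurement shown here bears on why the step has this direction or size.

The compounds shown leave open how a carboxylic acid or a primary amine would read in place of chloro on the aromatic carbon, para to a large group. They also leave open whether the two cores would remain indistinguishable with a longer chain at the amide nitrogen.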